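A ring exchange starting from compound 3

The compounds below may be only part of what the source reports. "The series", "measured", "known", "first", "only" and "open" are said of these compounds alone.

In an ADME assay on microsomes from liver (Rattus norvegicus) for metabolic stability (on this read-out lower numbers stand for a shorter-lived compound and higher numbers for a longer-lived compound), compound 3 `CC(C)C(c1noc(=O)[nH]1)c1ccc(-c2ccc3cccc(F)c3c2)[nH]c1=O` gives > 3 h, which is a limit of the assay and not a number. Compound 1 `CC(C)C(Nc1nnc[nH]1)c1ccc(-c2ccc3cccc(F)c3c2)[nH]c1=O` gives 1.29 h. Compound 4 `Cc1c[nH]c(C(c2ccc(-c3ccc4cccc(F)c4c3)[nH]c2=O)C(C)C)n1` differs from compound 3 by a group of 6 heavy atoms (4 carbon, 2 nitrogen; one five-membered aromatic ring with 2 hetero atoms) in place of a group of 6 heavy atoms (2 carbon, 2 nitrogen, 2 oxygen; one five-membered aromatic ring with 3 hetero atoms), on a saturated chain carbon bound to an aromatic carbon and a saturated chain carbon, on a saturated chain carbon bound to an aromatic carbon and a saturated chain carbon. Three measured changes at this place bear on it: a 13-fold lower number from compound 1 to compound 2 (1.12 log units; beyond the scatter), an at least 30-fold higher number from compound 2 to compound 3 (1.48 log units; beyond the scatter) and an at least 2.3-fold higher number from compound 1 to compound 3 (0.36 log units; beyond the scatter), all beyond the scatter. Compound 2 `CC(C)C(c1ncco1)c1ccc(-c2ccc3cccc(F)c3c2)[nH]c1=O`, at 0.0983 h, shares with compound 4 a five-membered aromatic ring with 2 hetero atoms, so a large fall is expected. The estimate is an at least 10-fold lower number from compound 3 to compound 4 (1.00 log units; beyond the scatter). For compound 4 the expected value is 0.3 h, with an estimated range of 0.08 h to 1.2 h.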

Compound 4, half-life: < 0.0667 h
Compound 4 gave a limit, no number; the forecaster's own chance of this, stated with the estimate: 3%; middle value at least 4.4-fold (0.65 log units) from the limit.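

Compound 4 gives a limit and not a number: the limit of < 0.0667 h in this assay, at which 1 of the 4 values shown sits. In this assay, placing 4-methyl-1H-imidazol-2-yl on this saturated chain carbon gives an at least 44-fold lower number from compound 3 to compound 4 (1.65 log units; beyond the scatter) and an at least 19-fold lower number from compound 1 to compound 4 (1.28 log units; beyond the scatter), so a second five-membered aromatic ring with 2 hetero atoms also sits far from the two longer-lived compounds. Against 1,3-oxazol-2-yl the result is an at least 1.4-fold lower number from compound 2 to compound 4 (0.16 log units; that floor lies within the scatter), so those two cannot be ranked.

The compounds shown leave open how far compound 4 lies past its limit and whether the methyl group matters. An imidazol-2-yl without methyl or a carboxylic acid at this place could address what the ring itself contributes.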